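The compounds below may be only part of what the source reports. "The series", "measured", "known", "first", "only" and "open" are said of these compounds alone.

Measured so far in a functional assay on PC-3 cells (Homo sapiens) for inhibition, read by MTT assay, with a stated time of 72 h; on this read-out lower numbers stand for stronger inhibition and higher numbers for weaker inhibition:

- compound 1 `O=C(CSc1nc(Nc2ccccc2)c2ccccc2n1)Nc1cccc(F)c1`: 15600 nM
- compound 2 `O=C(CSc1nc(Nc2ccccc2)c2ccccc2n1)Nc1cccc(Cl)c1`: 12600 nM
- compound 3 `C=CC(=O)Nc1cccc(NC(=O)CSc2nc(Nc3ccc(Cl)c(Cl)c3)c3ccccc3n2)c1`: 27600 nM

Compound 2 and compound 1 share a core and differ in one place: fluoro in place of chloro on an aromatic carbon. That step reads a 1.2-fold higher number from compound 2 to compound 1 (0.09 log units; within the scatter), so the two values sit within the scatter of each other and no order between them can be read. Compound 3 carries a different core; the difference between the two cores is not broken down here. Compound 3 has the highest number of the three, within the scatter of compound 1 and beyond it only against compound 2.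

Compound 4 `C=CC(=O)Nc1cccc(NC(=O)CSc2nc(Nc3ccc(F)c(Cl)c3)c3ccccc3n2)c1` is not yet measured. It differs from compound 3 by fluoro in place of chloro on an aromatic carbon. This is the same kind of change as from compound 2 to compound 1, though the surroundings differ: there the fluoro stands meta to a large group, here ortho to a chloro group and para to a large group. Resting on the step of a 1.2-fold higher number from compound 2 to compound 1 (0.09 log units; within the scatter), a similarly small step is expected from compound 3 to compound 4, a 1.1-fold higher number from compound 3 to compound 4 (0.04 log units; within the scatter). In this assay compound 4 is therefore estimated at 30000 nM, with a range from 12000 nM to 75000 nM.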

Compound 4, half-maximal inhibitory concentration: > 50000 nM
Compound 4: only a limit was reported; the forecaster's own chance of this, stated with the estimate: 15%; at least 1.6-fold (0.22 log units) between middle value and limit.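

In this assay, fluoro in place of chloro, taking 3,4-dichlorophenyl to 3-chloro-4-fluorophenyl, reads as an at least 1.8-fold higher number from compound 3 to compound 4 (0.25 log units; that floor lies within the scatter). As far as these compounds go, the value of compound 4, > 50000 nM, is a limit of the assay and not a number, so the step gives only a floor and its true size stays unknown. The change therefore cannot be said to carry from one core to the other with the same size, nor to behave differently on the two cores: the same change on two cores in this assay, a 1.2-fold higher number (0.09 log units; within the scatter) from compound 2 to compound 1 and an at least 1.8-fold higher number (0.25 log units; that floor lies within the scatter) from compound 3 to compound 4; the limit leaves it open whether they differ.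

The compounds shown leave open how a methyl, methoxy or trifluoromethyl group would read in place of the fluoro of the 3-chloro-4-fluorophenyl group, since only chloro and fluoro appear at that place on this core. They also leave open whether an amine or a carboxylic acid on the (3-chloro-4-fluorophenyl)amino part would give compound 4's core a value that can be read as a number rather than a limit.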